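The compounds below may be only part of what the source reports. "The series", "measured", "known", "first", "only" and "open" are said of these compounds alone.

Measured compounds in an ADME assay on S9 fraction from liver (Homo sapiens) for metabolic stability, with a stated time of 60 min; a higher number here means that more of the compound is left, a lower number that less of the compound is left:
- compound 1, `Cc1nc(-c2nc[nH]n2)ccc1-c1cnc2c(n1)N([C@H]1CC[C@@H](O)CC1)C(=O)CN2`, gives 100%
- compound 2, `COCCN1C(=O)CNc2ncc(-c3ccc(-c4nc[nH]n4)nc3C)nc21`, gives 100%
- compound 3, `Cc1nc(-c2nc[nH]n2)ccc1-c1cnc2c(n1)N(CC1CCOCC1)C(=O)CN2`, gives 100%

Compound 1 stands level with compounds 2 and 3 on these numbers. Its nearest neighbour is compound 2, with no change at the digits printed from compound 1 to compound 2 (within the scatter), and its furthest is compound 3, with no change at the digits printed from compound 1 to compound 3 (within the scatter). The remaining pair shows no change at the digits printed from compound 2 to compound 3 (within the scatter). All three groups on the amide-type nitrogen in the ring thus leave the readout in this assay where it is.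

Compound 4, `CO[C@H]1CC[C@H](N2C(=O)CNc3ncc(-c4ccc(-c5nc[nH]n5)nc4C)nc32)CC1`, is not yet measured. It differs from compound 1 as follows: 4-methoxycyclohexyl in place of 4-hydroxycyclohexyl on an amide-type nitrogen in a ring. For the measured compounds named here, the steps that bear on this are the two that change the same position from compound 1, namely no change at the digits printed from compound 1 to compound 2 (within the scatter) and no change at the digits printed from compound 1 to compound 3 (within the scatter); both lie within the scatter. Going by the values given here, since every substituent tried at this position so far has given the same readout, no step beyond the scatter is expected here either, and the estimated step is a number 5 percentage points lower from compound 1 to compound 4 (within the scatter).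

Compound 4 is therefore expected to give 95% in this assay, with a range from 80% to 100%.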

Compound 4, percent of the compound remaining: 82%
For compound 4 the middle estimate is 13 percentage points above the measured one; measured number inside the range.
By their numbers in this assay, from the lowest: compound 4; then compounds 1, 2 and 3 (each within the scatter of the next).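

For the compounds shown here, the position is not indifferent in this assay: the swap of 4-hydroxycyclohexyl for 4-methoxycyclohexyl gives a number 18 percentage points lower from compound 1 to compound 4 (beyond the scatter) and removes the hydrogen-bond donor of that group, the first change here to move the readout beyond the scatter. Compound 4 also separates from the other two, with a number 18 percentage points lower from compound 3 to compound 4 (beyond the scatter) and a number 18 percentage points lower from compound 2 to compound 4 (beyond the scatter) on the same position, yet compound 2 also carries a methoxy group and still gives 100% in this assay, so a methoxy group alone does not go with the lower number among these compounds. No measurement at hand accounts for the step.

Going by these compounds, whether a 4-ethoxycyclohexyl group would follow compound 4 or stay with compound 1 remains open. So does the outcome for a 4-aminocyclohexyl group or a carboxylic acid on the same ring.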